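Growing the amide side chain from methyl to sec-butyl

The source may hold more compounds than are shown below. What is called first, only, known or untested is meant among the compounds shown, and "the series" means these compounds.

Compound 1 `CC(C)C[C@@H](CO)NC(=O)c1cnc2ccccc2c1Cl` gives > 100 uM in an ADME assay on CCRF-CEM cells (Homo sapiens) for cytotoxicity; a lower number here means that less compound is tolerated, a higher number that more compound is tolerated; that value is a limit of the assay, not a number.
Compound 2 `COC(=O)CNC(=O)c1cnc2ccccc2c1Cl` gives > 100 uM in this assay, again a limit rather than a number.
Compound 3 `COC(=O)[C@H](C)NC(=O)c1cnc2ccccc2c1Cl` gives 81.3 uM in this assay.

For the measured compounds named here, compound 3 therefore holds the only real number among the three; the other two sit at a limit, so that the limit of > 100 uM in this assay, at which 2 of the 3 values shown sit, marks where most of the set stands. The step from compound 1 to compound 3 is an at least 1.2-fold lower number from compound 1 to compound 3 (0.08 log units; that floor lies within the scatter), and the step from compound 2 to compound 3 is an at least 1.2-fold lower number from compound 2 to compound 3 (0.08 log units; that floor lies within the scatter); both are floors that lie within the scatter. The pair of compound 1 and compound 2 shows two limits, a step that the two limits leave unreadable from compound 1 to compound 2.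

Compound 4 `CC[C@H](C)[C@H](NC(=O)c1cnc2ccccc2c1Cl)C(=O)OC` differs from compound 3 by sec-butyl in place of methyl on a saturated chain carbon bound to an amide-type nitrogen and a carbonyl carbon. Going by the values given here, the closest measured step is the one from compound 2 to compound 3, which changes the same carbon and was at least small. On that basis no change beyond the scatter is expected in this assay for compound 4, so a step of about a 1.2-fold lower number from compound 3 to compound 4 (0.06 log units; within the scatter) is estimated. Compound 4 is thus expected to give roughly 70 uM in this assay, within a range of 25 uM to 150 uM.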

Compound 4, half-maximal toxic concentration: 23.3 uM
The estimate for compound 4 lay 3.0-fold (0.48 log units) above the measured number, outside the stated range (below it).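

At the saturated chain carbon bound to an amide-type nitrogen and a carbonyl carbon, the step from hydrogen to methyl could be read only as a floor within the scatter, but sec-butyl in place of methyl gives a clear step in this assay: a 3.5-fold lower number from compound 3 to compound 4 (0.54 log units; beyond the scatter). Set against hydrogen on the same carbon, sec-butyl gives an at least 4.2-fold lower number from compound 2 to compound 4 (0.63 log units; beyond the scatter), so this carbon does not merely accept any group without consequence, and among these one-place changes the cells tolerate less of the compound carrying sec-butyl. Much of the set still reads only as a limit and not as a number: the limit of > 100 uM in this assay, at which 2 of the 4 values shown sit.

Going by these compounds, whether the branching of sec-butyl or simply its added carbons drive the step stays open, and an isopropyl group or a straight butyl chain on this carbon would help to separate the two. Also open, on these data alone, are the part played by the defined stereocentre of sec-butyl and the reading in this assay of a carboxylic acid in place of the methyl ester with sec-butyl kept.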